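The compounds below may be only part of what the source reports. "The series", "measured", "known", "first", "only" and "open" are said of these compounds alone.

Compound 1 `O=C(Nc1ccncc1)Nc1ccc(-c2nc(N3CC4CCC(C3)O4)c3cnn(C4CCC5(CC4)OCCO5)c3n2)cc1`: > 0.5 h
Compound 2 `CNC(=O)Nc1ccc(-c2nc(N3CC4CCC(C3)O4)c3cnn([C@H]4CC[C@@H](O)CC4)c3n2)cc1`: > 0.5 h

In an in vitro ADME assay on microsomes (Mus musculus) for metabolic stability (a higher number here means that the compound lasts longer, a lower number that the compound disappears faster), compound 2 gives > 0.5 h, which is a limit of the assay and not a number. Compound 1 gives > 0.5 h, and this too is a limit. Compound 2 therefore stands at the limit of > 0.5 h in this assay, at which 2 of the 2 values shown sit, and no exact half-life is known for either compound.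

Compound 3 `CNC(=O)Nc1ccc(-c2nc(N3CC4CCC(C3)O4)c3cnn(C4CCC(OC)(OC)CC4)c3n2)cc1` keeps the rest of compound 2 but changes the group on an aromatic nitrogen: a group of 10 heavy atoms (8 carbon, 2 oxygen; one six-membered non-aromatic ring of carbon only) in place of a group of 7 heavy atoms (6 carbon, 1 oxygen; one six-membered non-aromatic ring of carbon only), on an aromatic nitrogen. The 4-hydroxycyclohexyl group leaves, and the new group has no hydrogen-bond donors.

Among the compounds with values here, no measured step in this assay gives a size for such a change, so only a small downward move, not clearly beyond the usual scatter, is expected. The step is estimated as an at least 1.2-fold lower number from compound 2 to compound 3 (0.09 log units; that floor lies within the scatter). For compound 3 the expected half-life is 0.4 h, with an estimated range of 0.15 h to 1 h.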

Compound 3, half-life: 0.25 h
Estimate against measurement, compound 3: 1.6-fold (0.20 log units) above, and the stated range covers the measured number.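

In this assay, compound 3 gives the only exact half-life among the compounds shown, 0.25 h, so this position now has one value that is a number. Placing the new group, which has no hydrogen-bond donors, on the aromatic nitrogen in place of the 4-hydroxycyclohexyl group gives an at least 2.0-fold lower number from compound 2 to compound 3 (0.30 log units; that floor lies within the scatter). The value for compound 2 is a limit, so this step is a floor and not a full size: the limit of > 0.5 h in this assay, at which 2 of the 3 values shown sit.

On these data alone, the exact half-life of compound 2 stays open, and with it whether the change moves the number beyond the usual scatter. Also open, as far as these compounds go, is how a 4-aminocyclohexyl or a 4-methoxycyclohexyl group on this nitrogen would read in this assay, which would help separate the loss of the hydroxyl from the rest of the change.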